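A pyridinyl ether in place of a fluorophenyl ether

The compounds below may be only part of what the source reports. "The series", "measured", "known", "first", "only" and "open" are said of these compounds alone.

compound 1 `COc1cc(OC)c2c(=O)cc(C(=O)Nc3ccc(N4CCN(C)CC4)cc3)[nH]c2c1` — > 19800 nM
compound 2 `COc1cc(OC)c2c(=O)cc(C(=O)Nc3ccc(Oc4ccc(F)cc4)cc3)[nH]c2c1` — > 50000 nM

In a functional assay on HepG2 cells (Homo sapiens) for antiproliferative activity, with a stated time of 72 h (on this read-out lower numbers stand for an effect already at smaller amounts and higher numbers for an effect only at larger amounts of compound), compound 1 gives only a limit, > 19800 nM. Compound 2 likewise reaches only a limit in this assay, > 50000 nM. The step that the two limits leave unreadable from compound 1 to compound 2 thus stays unreadable, as the limit of > 19800 nM in this assay, at which 1 of the 2 values shown sits, and the limit of > 50000 nM in this assay, at which 1 of the 2 values shown sits, show. Compound 3 `COc1cc(OC)c2c(=O)cc(C(=O)Nc3ccc(Oc4cccnc4)cc3)[nH]c2c1` differs from compound 2 by pyridin-3-yl in place of 4-fluorophenyl on an oxygen on an aromatic ring. Among the measured compounds shown here, no measured step bears on this change, and nothing here sets compound 2 apart from the limit. The step to compound 3 is expected to be a number no higher from compound 2 to compound 3 (the limit leaves the size open). For compound 3 a value of 50000 nM is estimated, between 15000 nM and 150000 nM.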

Compound 3, half-maximal effective concentration: > 32100 nM
Compound 3 ended at the assay's limit (the forecaster's own chance of this, stated with the estimate: 80%); the middle value lies beyond the limit too.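

In this assay compound 3 gives only a limit, > 32100 nM. Compound 1 and compound 2 also give only limits, so no step among these compounds can be read. Going by these compounds, whether pyridin-3-yl and 4-fluorophenyl differ at all on this read-out stays open.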